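This account rests on a few compounds, and the source may have more. Where it says the series, first, only, none or still open, it means among the compounds named here.

Measured compounds in a functional assay on CHO-K1 cells for antagonist activity at transient receptor potential cation channel subfamily V member 1 (Homo sapiens), read by FLIPR; on this read-out lower numbers stand for stronger inhibition and higher numbers for weaker inhibition:
- compound 1 `CC(C(=O)NCc1ccc(C(F)(F)F)nc1N1CCC(Cc2cc(F)cc(F)c2)CC1)c1ccc(NS(C)(=O)=O)c(F)c1`: 24 nM
- compound 2 `CC(=O)OC1CCN(c2nc(C(F)(F)F)ccc2CNC(=O)C(C)c2ccc(NS(C)(=O)=O)c(F)c2)CC1`: 139 nM

Compound 2 holds the highest of the two numbers in this assay; its nearest neighbour is compound 1, and the step of a 5.8-fold higher number from compound 1 to compound 2 (0.76 log units; beyond the scatter) separates them. That step swaps a 3,5-difluorobenzyl on a saturated ring carbon for an acetoxy group.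

Compound 3 `CC(C(=O)NCc1ccc(C(F)(F)F)nc1N1CCC(OC(=O)C(C)(C)C)CC1)c1ccc(NS(C)(=O)=O)c(F)c1` is not yet measured. It differs from compound 2 in one place: tert-butyl in place of methyl on a carbonyl carbon. The acetoxy of compound 2 thereby becomes a ((tert-butyl)carbonyl)oxy group, while the rest of the molecule is unchanged.

Going by the values given here, no measured step addresses this change. Among the compounds with values here, the only step in hand, from compound 1 to compound 2, concerns a different part of the molecule, and it offers no direct guide to enlarging the ester. The change of methyl to tert-butyl on the carbonyl carbon is small in scope, so the step of a 1.4-fold lower number from compound 2 to compound 3 (0.14 log units; within the scatter) is expected to stay within or close to the scatter, with at most a slight lowering of the number. For compound 3 the expected value in this assay is therefore 100 nM, estimated between 40 nM and 250 nM.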

Compound 3, half-maximal inhibitory concentration: 45.2 nM
Compound 3: middle estimate off by 2.2-fold (0.34 log units), on the high side; measured number inside the range.
By their numbers in this assay, from the lowest: compounds 1 and 3 (each within the scatter of the next); then compound 2.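

In this assay, going by these compounds alone, the ester on the saturated ring carbon proves sensitive to what sits on its carbonyl carbon: tert-butyl in place of methyl gives a 3.1-fold lower number from compound 2 to compound 3 (0.49 log units; beyond the scatter) and so moves the number beyond the scatter, whereas the earlier compounds showed only that acetoxy and 3,5-difluorobenzyl stand apart. The ((tert-butyl)carbonyl)oxy group stands level with 3,5-difluorobenzyl on that ring carbon, with a 1.9-fold higher number from compound 1 to compound 3 (0.27 log units; within the scatter) and thus no separation beyond the scatter, so the higher number seen with acetoxy does not hold for both esters shown at this position. Nothing available here offers an explanation for either step.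

Only methyl and tert-butyl are shown on this carbonyl carbon, so it remains open whether an ethyl or isopropyl group there would give a number closer to that of compound 2 or that of compound 3. As far as these compounds go, it also remains open whether the ester linkage itself matters, a question that an amide or an ether carrying the same tert-butyl on the ring carbon could answer.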